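The source may hold more compounds than are shown below. What is called first, only, known or untested is meant among the compounds shown, and "the series" means these compounds.

Values in an assay on membranes from striatum (strain Sprague-Dawley) for displacement of a labelled ligand from sodium-dependent dopamine transporter (Rattus norvegicus), read by scintillation counting, with a stated time of 120 min; on this read-out lower numbers stand for stronger inhibition and higher numbers for weaker inhibition:
compound 1 `Fc1ccc(C(SCCNC2CCN(Cc3ccc(C(F)(F)F)cc3)CC2)c2ccc(F)cc2)cc1`: 190 nM
compound 2 `O=C(c1cc2ccccc2[nH]1)N1CCC(NCCSC(c2ccc(F)cc2)c2ccc(F)cc2)CC1`: 177 nM
compound 3 `Fc1ccc(C(SCCNC2CCN(Cc3cc4ccccc4[nH]3)CC2)c2ccc(F)cc2)cc1`: 179 nM

Compound 3 gives the second highest of the three numbers, yet all three sit within the scatter of one another: a 1.1-fold lower number from compound 1 to compound 3 (0.03 log units; within the scatter), a 1.0-fold higher number from compound 2 to compound 3 (0.00 log units; within the scatter), and likewise a 1.1-fold lower number from compound 1 to compound 2 (0.03 log units; within the scatter). The group attached to the amine nitrogen in the ring has therefore been varied twice, once in the aromatic part and once in the linking unit, without any step beyond the scatter.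

Compound 4 `Fc1ccc(C(SCCNC2CCN(Cc3cc4ccccc4o3)CC2)c2ccc(F)cc2)cc1` is not yet measured. The change from compound 3 is 1-benzofuran-2-yl in place of 1H-indol-2-yl on a saturated chain carbon bound to an amine nitrogen in a ring. The measured steps that bear on this place are a 1.1-fold lower number from compound 1 to compound 3 (0.03 log units; within the scatter), which exchanged the aromatic part on the same saturated chain carbon, and a 1.0-fold higher number from compound 2 to compound 3 (0.00 log units; within the scatter), which altered the unit linking that aromatic part to the ring nitrogen; both were within the scatter. Among the compounds with values here, no measured pair tests the exchange of a hydrogen-bond donor for a hydrogen-bond acceptor within this bicyclic group, so that aspect is untested. On the steps available, the expected step of a 1.2-fold higher number from compound 3 to compound 4 (0.09 log units; within the scatter) is none beyond the scatter. Compound 4 is therefore estimated to give 220 nM in this assay, with a range of 100 nM to 500 nM.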

Compound 4, inhibition constant: 120 nM
Estimate against measurement, compound 4: 1.8-fold (0.26 log units) above, and the stated range covers the measured number.
By their numbers in this assay, from the lowest: compounds 4, 2, 3 and 1 (each within the scatter of the next).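

In this assay, replacing 1H-indol-2-yl with 1-benzofuran-2-yl on a saturated chain carbon bound to an amine nitrogen in a ring gives a 1.5-fold lower number from compound 3 to compound 4 (0.17 log units; within the scatter). Within the data shown here, this is the first measured pair to exchange a hydrogen-bond donor for a hydrogen-bond acceptor within this bicyclic group, and the exchange leaves the number within the scatter. The two wider comparisons, a 1.5-fold lower number from compound 2 to compound 4 (0.17 log units; within the scatter) and a 1.6-fold lower number from compound 1 to compound 4 (0.20 log units; within the scatter), also stay within the scatter, and nothing on hand bears further on this result.

Still open, on these data alone, is whether any group on the ring nitrogen can produce a step beyond the scatter, for example a cyclohexylmethyl group, or a longer chain that sets the bicyclic group further from that nitrogen. Also open, as far as these compounds go, is whether (1-benzofuran-2-yl)carbonyl on the ring nitrogen would match (1H-indol-2-yl)carbonyl, and whether replacing the oxygen of 1-benzofuran-2-yl with sulfur, as in 1-benzothiophen-2-yl, would leave the number within the scatter.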